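The source may hold more compounds than are shown below. What is called first, only, known or untested is meant among the compounds shown, and "the series" means these compounds.

Compound 1 `O=C(O)c1ccc2nc(N3CCC(OCc4c(-c5c(Cl)cccc5Cl)noc4C4CC4)CC3)sc2c1` gives 0.58 in an ADME assay on microsomes from liver (Rattus norvegicus); on this read-out higher numbers stand for higher hepatic extraction and lower numbers for lower hepatic extraction. Compound 2 `O=C(O)c1ccc2nc(N3CCC(OCc4c(-c5c(F)cccc5F)noc4C4CC4)CC3)sc2c1` gives 0.52 in this assay.

Compound 2 has the lowest of these two numbers, with compound 1 nearest and a step of a number 0.060 lower from compound 1 to compound 2 (within the scatter). Compound 3 `O=C(O)c1ccc2nc(N3CCC(OCc4c(-c5ccccc5C(F)(F)F)noc4C4CC4)CC3)sc2c1` differs from compound 2 by 2-(trifluoromethyl)phenyl in place of 2,6-difluorophenyl on an aromatic carbon. Within the data shown here, the only measured step, a number 0.060 lower from compound 1 to compound 2 (within the scatter), also swaps one halogenated phenyl for another at this same carbon and stays within the scatter, so a step of about a number 0.030 higher from compound 2 to compound 3 (within the scatter) is expected, which is not beyond the scatter. Compound 3 is therefore estimated at 0.55, likely between 0.4 and 0.7.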

Compound 3, hepatic extraction ratio in the liver assay: 0.5
The estimate for compound 3 lay 0.050 above the measured number, and the stated range covers the measured number.
By their numbers in the liver assay, from the lowest: compounds 3, 2 and 1 (each within the scatter of the next).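

At this aromatic carbon, 2-(trifluoromethyl)phenyl reads the same as both halogenated phenyl groups in the liver assay, with a number 0.020 lower from compound 2 to compound 3 (within the scatter) and a number 0.080 lower from compound 1 to compound 3 (within the scatter). In a physicochemical assay for solubility, in simulated intestinal fluid, at pH 6.8 (a higher number here means a more soluble compound, a lower number a less soluble compound), compound 2 gives 169000 nM and compound 3 gives 131000 nM, which is a 1.3-fold lower number from compound 2 to compound 3 (0.11 log units; within the scatter), so neither read-out separates this pair. Nothing available explains why these groups read alike.

Still open, as far as these compounds go, is whether a phenyl carrying an amine or a nitrile would shift either read-out at this carbon, and whether this flat picture extends beyond these three compounds.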